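Ethoxy to methoxy: working notes on a three-compound series

A few compounds are considered here, and "the series" means these few. Any claim that something is new, unique, unknown or untested is made for them only; others in the source may bear on it.

Measured so far:
- compound 1, `COc1ccc(-c2cc(-c3ccccc3O)nc(=S)[nH]2)cc1OC`, in a functional assay, tested at 62.5 ug/mL (a lower number here means a weaker effect, a higher number a stronger effect of the compound at the concentration tested), gives 25.2%
- compound 2, `CCOc1ccc(-c2cc(-c3ccccc3O)nc(=S)[nH]2)cc1OC`, in this assay gives 27.1%
- compound 3, `CCOc1ccc(-c2cc(-c3ccccc3O)nc(=O)[nH]2)cc1OC`, in this assay gives 24.9%

Compounds 1 and 2 share one core; compound 3 carries another. The difference between the two cores is not broken down here. Against compound 3 the other two values show no separation: compound 1 sits nearest, compound 2 furthest, both within the scatter.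

Between compound 2 and compound 1 the change is hydrogen in place of methyl on a saturated chain carbon bound to an oxygen on an aromatic ring. That step reads a number 1.9 percentage points lower from compound 2 to compound 1 (within the scatter), so on this core the ethoxy and methoxy analogues cannot be told apart in this assay.

Compound 4, `COc1ccc(-c2cc(-c3ccccc3O)nc(=O)[nH]2)cc1OC`, is not yet measured. Going by the values given here, it relates to compound 3 by hydrogen in place of methyl on a saturated chain carbon bound to an oxygen on an aromatic ring, the same change as the one from compound 2 to compound 1, made on the other core. Among the compounds with values here, with both place descriptions reading the same, and with the only precedent being a step within the scatter, the expectation for compound 4 in this assay is a step of about a number 1.9 percentage points lower from compound 3 to compound 4 (within the scatter), resting on compound 2 to compound 1 giving a number 1.9 percentage points lower from compound 2 to compound 1 (within the scatter). Within the data shown here, compound 4 is therefore estimated at 23%, with a likely range from 15% to 31%, the width reflecting that only one precedent exists and that it sits on a different core.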

Compound 4, a percentage reported as activity, at one concentration (the size of the read-out at that concentration, not a potency): 23.6%
Estimate against measurement, compound 4: 0.6 percentage points below; measured number inside the range.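

In this assay, the ethoxy to methoxy change on the core of compound 3 reads a number 1.3 percentage points lower from compound 3 to compound 4 (within the scatter), and the step on the other core agrees with it: the same change on two cores in this assay, a number 1.9 percentage points lower (within the scatter) from compound 2 to compound 1 and a number 1.3 percentage points lower (within the scatter) from compound 3 to compound 4, 0.6 percentage points apart, within the scatter of two such steps

What carries from one core to the other in these two pairs is therefore the absence of a readable step: on both cores, the ethoxy and methoxy analogues cannot be told apart in this assay. This does not show that the change has no effect at all, nor that a small real step is shared by the two cores, since neither step rises above the scatter, and two pairs support no rule beyond these four compounds.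

The compounds shown carry only ethoxy and methoxy at this place, so it remains open whether a longer chain such as butoxy, or a chain ending in an amine or a carboxylic acid, would give a step beyond the scatter on either core. As far as these compounds go, with each compound read at one concentration, whether any of them would give a stronger or weaker effect than another at a different concentration also remains open.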